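Replacing the sulfur-bearing group with 4-acetylpiperazin-1-yl

The compounds below may be only part of what the source reports. "The series", "measured", "known", "first", "only" and "open" are said of these compounds alone.

Going by the values given here, in a functional assay on MGC-803 cells (Homo sapiens) for inhibition, read by CCK-8 assay, with a stated time of 48 h (a higher number here means a weaker inhibitor, a lower number a stronger inhibitor), compound 1 `COc1ccc(CN(C(=O)CSc2nc3ccccc3o2)c2cc(OC)c(OC)c(OC)c2)cc1` gives 450 nM and compound 2 `COc1ccc(CN(C(=O)CSC(=S)N2CCN(C(C)=O)CC2)c2cc(OC)c(OC)c(OC)c2)cc1` gives 480 nM, so compound 2 stands level with the only other measured number. The next structure is compound 3 `COc1ccc(CN(C(=O)CN2CCN(C(C)=O)CC2)c2cc(OC)c(OC)c(OC)c2)cc1`, and the change is a group of 9 heavy atoms (6 carbon, 2 nitrogen, 1 oxygen; one six-membered non-aromatic ring with 2 hetero atoms) in place of a group of 12 heavy atoms (7 carbon, 2 nitrogen, 1 oxygen, 2 sulfur; one six-membered non-aromatic ring with 2 hetero atoms), on a saturated chain carbon bound to a carbonyl carbon. Both groups carry one six-membered non-aromatic ring with 2 hetero atoms, but the entering 4-acetylpiperazin-1-yl group holds no sulfur.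

Among the compounds with values here, only one measured step bears on this change: a 1.1-fold higher number from compound 1 to compound 2 (0.03 log units; within the scatter), which lies within the scatter despite a large exchange of groups. That step offers limited guidance, since compound 1 and compound 2 both keep a sulfur on the saturated chain carbon bound to a carbonyl carbon, whereas compound 3 does not. The data therefore do not test this kind of change, and a modest loss in this assay is expected, with no change remaining possible. The expected step is a 1.9-fold higher number from compound 2 to compound 3 (0.27 log units; within the scatter), and this estimate is loose. For compound 3 the estimated value is 900 nM, with an expected range of 250 nM to 3500 nM.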

Compound 3, half-maximal inhibitory concentration: 12800 nM
Estimate against measurement, compound 3: 14-fold (1.15 log units) below; the whole stated range lies below it.
By their numbers in this assay, from the lowest: compounds 1 and 2 (each within the scatter of the next); then compound 3.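

In this assay, the saturated chain carbon bound to a carbonyl carbon does not accept every group, as the flat step between the two sulfur-linked groups might have suggested: removing the sulfur-bearing link from the group in compound 2 gives (a 27-fold higher number from compound 2 to compound 3 (1.43 log units; beyond the scatter)). The six-membered ring and its acetyl group remain in compound 3, so this large step goes with the loss of the sulfur-bearing link, not with the loss of the ring. The exchange of (1,3-benzoxazol-2-yl)sulfanyl for 4-acetylpiperazin-1-yl gives a step of similar reading (a 28-fold higher number from compound 1 to compound 3 (1.45 log units; beyond the scatter)), and nothing available explains the loss in either step.

The compounds shown do not separate the sulfur atoms from the length of the link, so it stays open whether either one alone carries the effect. A longer carbon chain ending in 4-acetylpiperazin-1-yl, or an oxygen atom as the link in place of sulfur on the (1,3-benzoxazol-2-yl)sulfanyl group, would pull these two apart.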